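The compounds below may be only part of what the source reports. "The series", "measured", "known", "first", "only" and "open" are said of these compounds alone.

Three compounds share one core and differ only in the group carried on an oxygen on a saturated carbon. Compound 1 `CNC(=O)c1cc(OCCCCOc2ccc(C(=O)CC(C)(C)C)c(O)c2C)ccc1F` gives 164 nM in an assay for positive allosteric modulation of metabotropic glutamate receptor 2 (Rattus norvegicus); on this read-out lower numbers stand for an effect already at smaller amounts and higher numbers for an effect only at larger amounts of compound. Compound 2 `Cc1cc(C(=O)O)ccc1OC[C@H](C)COc1ccc(C(=O)CC(C)(C)C)c(O)c1C` gives 446 nM in this assay, and compound 3 `Cc1cc(OC[C@H](C)COc2ccc(C(=O)CC(C)(C)C)c(O)c2C)ccc1C(=O)O` gives 305 nM. Among these three numbers compound 3 stands second highest; its nearest neighbour is compound 2, and the step of a 1.5-fold lower number from compound 2 to compound 3 (0.17 log units; within the scatter) lies within the scatter, as does the gap between compound 3 and compound 1. Compound 4 `COc1cccc(OC[C@H](C)COc2ccc(C(=O)CC(C)(C)C)c(O)c2C)c1` has not yet been measured. The change is 3-methoxyphenyl in place of 4-carboxy-3-methylphenyl on an oxygen on a saturated carbon. For the measured compounds named here, no measured step bears directly on this change: the one measured step only exchanges one carboxy-methylphenyl for another, and compound 1 carries a different linking chain together with a different group, so it cannot be set against compound 3 in a single step. The expectation therefore rests on the three numbers staying close together across rather different groups in that position, and for compound 4 the expected step is a 1.0-fold lower number from compound 3 to compound 4 (0.01 log units; within the scatter), with no direction favoured beyond the scatter. Compound 4 is expected to give 300 nM in this assay, within a range from 80 nM to 1200 nM.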

Compound 4, half-maximal effective concentration: "not active" (no number reported)
Compound 4 has no reported number here, and the estimate cannot be compared.
By their numbers in this assay, from the lowest: compounds 1, 3 and 2 (each within the scatter of the next, the first and the last beyond it).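

Compound 4 is reported as "not active" in this assay, with no number, so no step from compound 3 to compound 4 can be read, and nothing available explains this result. Still open, from the compounds shown here alone, is which part of the exchange of 4-carboxy-3-methylphenyl for 3-methoxyphenyl goes with this outcome.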